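The source may report more compounds than this note shows. Statements on the series, on what has been measured and on what is new or still open speak of the compounds shown alone.

Measured compounds in an ADME assay on CCRF-CEM cells (Homo sapiens) for cytotoxicity, read by MTT assay, with a stated time of 5 days; a higher number here means that more compound is tolerated, a lower number that less compound is tolerated:
Compound 1, `COc1cc(Cc2cnc(/N=C3\C(=O)N(CN4CCCCC4C)c4ccc(Cl)cc43)nc2N)cc(OC)c1OC`, gives > 83.8 ug/mL, which is a limit of this assay rather than a number.
Compound 2, `COc1cc(Cc2cnc(/N=C3\C(=O)N(CN4CCC(C)CC4)c4ccc(Cl)cc43)nc2N)cc(OC)c1OC`, gives 46.3 ug/mL.
Compound 3, `COc1cc(Cc2cnc(/N=C3\C(=O)N(CN4CCN(C)CC4)c4ccc(Cl)cc43)nc2N)cc(OC)c1OC`, gives 88 ug/mL.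

Compound 1 therefore stands only at a limit, with no exact number; this is the limit of > 83.8 ug/mL in this assay, at which 1 of the 3 values shown sits. Compound 4, `COc1cc(Cc2cnc(/N=C3\C(=O)N(CN4CCN(c5ccccn5)CC4)c4ccc(Cl)cc43)nc2N)cc(OC)c1OC`, differs from compound 1 by one change: 4-(pyridin-2-yl)piperazin-1-yl in place of 2-methylpiperidin-1-yl on a saturated chain carbon bound to an amide-type nitrogen in a ring. The measured steps all change the same group at the same place. The step of an at least 1.8-fold lower number from compound 1 to compound 2 (0.25 log units; that floor lies within the scatter) and the step of a 1.9-fold higher number from compound 2 to compound 3 (0.28 log units; within the scatter) both stay within the usual scatter, and the step that the limit leaves unreadable from compound 1 to compound 3 cannot be read because of the limit. None of these steps introduces a group as large as the 4-(pyridin-2-yl)piperazin-1-yl group, so they give no guide to its direction. The expectation is therefore a step of about an at least 1.2-fold lower number from compound 1 to compound 4 (0.11 log units; that floor lies within the scatter), no larger than the scatter. Compound 4 is estimated to give about 65 ug/mL in this assay, within a range from 30 ug/mL to 110 ug/mL.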

Compound 4, half-maximal cytotoxic concentration: 29.4 ug/mL
Compound 4: the middle estimate sits 2.2-fold (0.34 log units) above what was measured, and the stated range ends above it.
By their numbers in this assay, from the lowest: compounds 4, 2 and 3 (each within the scatter of the next, the first and the last beyond it).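

In this assay, among these compounds, pyridin-2-yl gives the first step at this place that is clearly beyond the scatter, with pyridin-2-yl in place of methyl on an amine nitrogen in a ring: a 3.0-fold lower number from compound 3 to compound 4 (0.48 log units; beyond the scatter). The full 4-(pyridin-2-yl)piperazin-1-yl group gives an at least 2.8-fold lower number from compound 1 to compound 4 (0.45 log units; beyond the scatter) when it replaces 2-methylpiperidin-1-yl, but a 1.6-fold lower number from compound 2 to compound 4 (0.20 log units; within the scatter) when it replaces 4-methylpiperidin-1-yl, so what the change shows depends on which group leaves. Compound 1 stands only at a limit: the limit of > 83.8 ug/mL in this assay, at which 1 of the 4 values shown sits.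

As far as these compounds go, it remains open whether the ring nitrogen of pyridin-2-yl matters, since a phenyl group on the same amine nitrogen would be the direct comparison. A benzyl group there could also show whether the aromatic ring must sit directly on that nitrogen.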